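The compounds below may be only part of what the source reports. "The series", "measured", "known", "first", "only" and "open" are said of these compounds alone.

Measured compounds, with binding in an assay on CHO cells for displacement of a labelled ligand from 5-hydroxytryptamine receptor 1D (Homo sapiens); a lower number here means a stronger inhibitor, a higher number a weaker inhibitor:

- compound 1 `CN(Cc1ccccc1)CC1CCN(CCCc2c[nH]c3ccc(-n4cnnc4)cc23)CC1`: 0.9 nM
- compound 2 `CC(=O)Nc1ccc([C@H](C)NCC2CCN(CCCc3c[nH]c4ccc(-n5cnnc5)cc34)CC2)cc1`: 0.6 nM
- compound 3 `O[C@@H]1Cc2ccccc2[C@H]1NC1CCN(CCCc2c[nH]c3ccc(-n4cnnc4)cc23)CC1`: 6.6 nM

Within this small set compound 1 sits second highest of the three numbers; its nearest neighbour is compound 2, whose value lies within the scatter of that of compound 1, and the furthest is compound 3, reached by a 7.3-fold higher number from compound 1 to compound 3 (0.87 log units; beyond the scatter), a modest step beyond the scatter.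

The unmeasured compound 4 `C[C@H](NCC1CCN(CCCc2c[nH]c3ccc(-n4cnnc4)cc23)CC1)c1ccccc1` is built from the same atoms as compound 1, joined differently: (1-phenylethyl)amino in place of benzyl(methyl)amino on a saturated chain carbon bound to a saturated ring carbon. Among the compounds with values here, only one measured step bears on this position, the change from compound 1 to compound 3, and it moved the number upward by a modest amount. That step, however, replaced the group with a larger bicyclic amine, whereas compound 4 keeps a single phenyl ring on the chain. Compound 2, whose structure carries a closely related (1-phenylethyl)amino arrangement on the same chain carbon, gives a value within the scatter of compound 1. On balance the step into compound 4 is expected to stay within the scatter, a 1.1-fold higher number from compound 1 to compound 4 (0.05 log units; within the scatter). The value of compound 4 in this assay is therefore estimated at 1 nM, with a range from 0.3 nM to 3.5 nM.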

Compound 4, half-maximal inhibitory concentration: 4.4 nM
Beside the measured number, compound 4's estimate is 4.4-fold (0.64 log units) below it, and the stated range ends below it.
By their numbers in this assay, from the lowest: compounds 2 and 1 (each within the scatter of the next); then compounds 4 and 3 (each within the scatter of the next).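

In (this assay), exchanging benzyl(methyl)amino for (1-phenylethyl)amino on a saturated chain carbon bound to a saturated ring carbon is a real change even though the heavy-atom count stays the same (a 4.9-fold higher number from compound 1 to compound 4 (0.69 log units; beyond the scatter)), and the entering group brings a hydrogen-bond donor and a defined stereocentre that the leaving group lacks. The acetamido group can now be read on its own, since hydrogen in its place on an aromatic carbon gives a step beyond the scatter (a 7.3-fold higher number from compound 2 to compound 4 (0.87 log units; beyond the scatter)), so the close values of compound 1 and compound 2 do not reflect an equivalence of the two amine groups. The ((1-phenylethyl)amino)methyl group also stands level with the (2-hydroxy-2,3-dihydro-1H-inden-1-yl)amino group (a 1.5-fold lower number from compound 3 to compound 4 (0.18 log units; within the scatter)), and nothing available here accounts for any of these steps.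

The compounds shown leave open whether the step from compound 1 to compound 4 follows the hydrogen-bond donor or the stereocentre, which a tertiary amine carrying both a methyl and a 1-phenylethyl group could help separate. They also leave open the opposite stereocentre and whether a methoxy group or a carboxylic acid in place of acetamido would behave like acetamido or like hydrogen.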